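The compounds below may be only part of what the source reports. "The series", "measured", "known", "first", "only" and "open" are said of these compounds alone.

Measured in a functional assay on PC-3 cells (Homo sapiens) for cytotoxicity, read by sulforhodamine B assay, with a stated time of 48 h; on this read-out higher numbers stand for weaker inhibition and lower numbers for stronger inhibition:
- compound 1 `C[C@H]1CC[C@@H]2[C@@H](OC(=O)[C@]23CC(c2ccc(Cl)cc2)=NO3)[C@]2(C)C(=O)C=C[C@@]12O`: 49000 nM
- compound 2 `C[C@H]1CC[C@@H]2[C@@H](OC(=O)[C@]23CC(c2ccccc2)=NO3)[C@]2(C)C(=O)C=C[C@@]12O`: 46000 nM
- compound 3 `C[C@H]1CC[C@@H]2[C@@H](OC(=O)[C@]23CC(c2ccc(N(C)C)cc2)=NO3)[C@]2(C)C(=O)C=C[C@@]12O`: 6300 nM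

Compound 2 sits at the high end of these numbers together with compound 1, with a 1.1-fold lower number from compound 1 to compound 2 (0.03 log units; within the scatter). Compound 3 lies clearly lower, with a 7.8-fold lower number from compound 1 to compound 3 (0.89 log units; beyond the scatter) and a 7.3-fold lower number from compound 2 to compound 3 (0.86 log units; beyond the scatter).

Compound 4 `COc1cc(C2=NO[C@]3(C2)C(=O)O[C@@H]2[C@H]3CC[C@H](C)[C@]3(O)C=CC(=O)[C@@]23C)ccc1O` is unmeasured and differs from compound 2 as follows: 4-hydroxy-3-methoxyphenyl in place of phenyl on a carbon with a double bond to nitrogen. For the measured compounds named here, no measured compound carries hydroxy or methoxy, so the evidence is indirect. It rests on the two steps above that start from compound 2 or end there. A move towards a lower number in this assay is expected, smaller than a 7.3-fold lower number from compound 2 to compound 3 (0.86 log units; beyond the scatter).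

The estimated step is a 2.1-fold lower number from compound 2 to compound 4 (0.32 log units; beyond the scatter).

For compound 4 the expected value is 22000 nM, with an estimated range of 7000 nM to 60000 nM.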

Compound 4, half-maximal inhibitory concentration: 16000 nM
The estimate for compound 4 lay 1.4-fold (0.14 log units) above the measured number, and the stated range covers the measured number.
By their numbers in this assay, from the lowest: compound 3; then compound 4; then compounds 2 and 1 (each within the scatter of the next).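

In this assay, this position takes a ring bearing both hydroxy and methoxy and the number falls, not only with dimethylamino: 4-hydroxy-3-methoxyphenyl in place of phenyl gives a real step (a 2.9-fold lower number from compound 2 to compound 4 (0.46 log units; beyond the scatter)), and the same holds against 4-chlorophenyl (a 3.1-fold lower number from compound 1 to compound 4 (0.49 log units; beyond the scatter)). The step does not reach the level of 4-(dimethylamino)phenyl (a 2.5-fold higher number from compound 3 to compound 4 (0.40 log units; beyond the scatter)).

Still open, as far as these compounds go, is whether hydroxy or methoxy alone accounts for the step, and whether a primary amine or a carboxylic acid on this ring would follow compound 3 or compound 4. No measurement at hand bears on the reason for these steps.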